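Swapping the pyrimidine for a fluoropyridyl ether on the benzyl arm

This account rests on a few compounds, and the source may have more. Where it says the series, first, only, none or still open, it means among the compounds named here.

Compound 1, `O=C1C(=O)N(Cc2ccc(-c3cncnc3)cc2)c2ccc(OC(F)(F)F)cc21`: 2100 nM
Compound 2, `O=C1C(=O)N(Cc2cccc(-c3ccccc3)c2)c2ccc(OC(F)(F)F)cc21`: > 30000 nM

Of the compounds shown here, two have been measured so far in a functional assay on CHO cells for positive allosteric modulation of muscarinic acetylcholine receptor M5 (Homo sapiens), read by FLIPR and calcium flux, with a stated time of 1 h; a lower number here means that less compound is needed, a higher number that more compound is needed for the effect. Compound 1, carrying a pyrimidin-5-yl group on its benzyl ring, gives 2100 nM. Compound 2, whose phenyl group sits on the benzyl ring in a different arrangement, reaches only the limit of the assay, > 30000 nM; this is a limit and not a number, as recorded in the limit of > 30000 nM in this assay, at which 1 of the 2 values shown sits. Among the compounds with values here, compound 1 therefore stands alone as the only compound with a numerical value in this assay, and no step between two measured compounds with a single point of difference is available.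

Compound 3, `O=C1C(=O)N(Cc2ccc(Oc3cccc(F)n3)cc2)c2ccc(OC(F)(F)F)cc21`, keeps the shared core of compound 1 and alters only the benzyl arm: (6-fluoropyridin-2-yl)oxy in place of pyrimidin-5-yl on an aromatic carbon. The place of the change is the same as in compound 1, on the aromatic carbon para to a large group, so the arrangement that gave compound 1 its measurable value is retained.

Within the data shown here, with no measured step to lean on, the change is expected to move compound 3 by a modest amount, within or close to the scatter. Compound 3 is expected to give about 1500 nM, within 400 nM to 6000 nM. The estimated step from compound 1 to compound 3 is a 1.4-fold lower number from compound 1 to compound 3 (0.15 log units; within the scatter).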

Compound 3, half-maximal effective concentration: 1500 nM
For compound 3 middle estimate and measured number coincide at the digits printed; measured number inside the range.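

In this assay the exchange of pyrimidin-5-yl for (6-fluoropyridin-2-yl)oxy gives a 1.4-fold lower number from compound 1 to compound 3 (0.15 log units; within the scatter), so the two groups cannot be told apart in this read-out. Within the data shown here, this is the only step available so far, and it shows that the aromatic carbon para to a large group can carry a group with a larger heavy-atom count, an oxygen link, a fluorine and one ring nitrogen in place of two, with no difference beyond the scatter. No measurement shown bears on why the two groups read alike.

From the compounds shown here alone, both groups at this place carry a six-membered aromatic ring, so how a group without one, such as an amine or a carboxylic acid, would read there stays open, as does the separate share of the oxygen link and of the fluorine within the new group. Compound 2 has only a limit and not a number, and it differs from the others in more than one place, so the arrangement of the benzyl arm cannot be judged from it as a single step.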